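Aryl variation on the shared core: working notes

The compounds below may be only part of what the source reports. "The series", "measured", "known", "first", "only" and "open" are said of these compounds alone.

Measured compounds in a functional assay on the whole organism for inhibition, with Mythimna separata as the target, with a stated time of 5 days; on this read-out higher numbers stand for an effect only at larger amounts of compound and lower numbers for an effect already at smaller amounts:
compound 1 `CC(C)(C)n1ncc(OCc2nnc(-c3cccc(F)c3)o2)c(Cl)c1=O` gives 7.1 ug/mL
compound 2 `CC(C)(C)n1ncc(OCc2nnc(-c3ccccc3)o2)c(Cl)c1=O` gives 12.2 ug/mL

Compound 2 holds the highest of the two numbers in this assay, and its nearest neighbour is compound 1; the step of a 1.7-fold higher number from compound 1 to compound 2 (0.24 log units; within the scatter), hydrogen in place of fluoro on an aromatic carbon, lies within the scatter. Compound 3 `CC(C)(C)n1ncc(OCc2nnc(-c3ccc(Cl)cc3Cl)o2)c(Cl)c1=O` is not yet measured. Among the measured compounds shown here, the change (2,4-dichlorophenyl in place of phenyl on an aromatic carbon), 2,4-dichlorophenyl in place of phenyl on an aromatic carbon, has no direct precedent among the measured pairs. For the measured compounds named here, the only measured step concerns a single fluoro on the same aromatic ring, and that step was within the scatter, so no direction is supported for this larger change. The expectation for compound 3 is therefore no step beyond the scatter, a 1.4-fold lower number from compound 2 to compound 3 (0.13 log units; within the scatter). Compound 3 is estimated at 9 ug/mL, with a range of 3 ug/mL to 30 ug/mL in this assay.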

Compound 3, half-maximal effective concentration: 27.8 ug/mL
The estimate for compound 3 lay 3.1-fold (0.49 log units) below the measured number; measured number inside the range.
By their numbers in this assay, from the lowest: compounds 1 and 2 (each within the scatter of the next); then compound 3.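

In this assay, the aryl group on the five-membered aromatic ring with 2 nitrogen and 1 oxygen now shows a change beyond the scatter when 2,4-dichlorophenyl enters in place of phenyl (a 2.3-fold higher number from compound 2 to compound 3 (0.36 log units; beyond the scatter)). The same group in place of 3-fluorophenyl gives a step that is also beyond the scatter (a 3.9-fold higher number from compound 1 to compound 3 (0.59 log units; beyond the scatter)), so this position is not indifferent to the aryl group, and both steps run towards an effect only at larger amounts of compound. No measurement available here accounts for these steps.

Whether a single chlorine on the phenyl would give a similar step remains open, since only the 2,4-dichlorophenyl case is shown. Also open, going by these compounds, is how a methoxy or an amine on this ring would read in this assay relative to these three compounds.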